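Cytotoxicity series: trimming the benzyl arm to isopropyl

This account rests on a few compounds, and the source may have more. Where it says the series, first, only, none or still open, it means among the compounds named here.

Compound 1 `COc1ccc(F)cc1CNCCCNc1ccnc2cc(Cc3cc(C)cc(C)c3)ccc12` gives 940 nM in an ADME assay on HepG2 cells (Homo sapiens) for cytotoxicity, read by luminescence, CellTiter-Glo and ATP content, with a stated time of 72 h; a lower number here means that less compound is needed, a higher number that more compound is needed for the effect.
Compound 2 `COc1cccc(Oc2ccc3c(NCCCNCc4cc(F)ccc4OC)ccnc3c2)c1` gives 7100 nM in this assay.
Compound 3 `COc1ccc(F)cc1CNCCCNc1ccnc2cc(CCc3ccccc3)ccc12` gives 4240 nM in this assay.

Compound 3 sits second highest of the three numbers; it is within scatter of compound 2 and well apart from compound 1, as a 4.5-fold higher number from compound 1 to compound 3 (0.65 log units; beyond the scatter) shows. Compound 4 `COc1ccc(F)cc1CNCCCNc1ccnc2cc(CC(C)C)ccc12` carries isopropyl in place of benzyl on a saturated chain carbon bound to an aromatic carbon. For the measured compounds named here, the one step that bears on this kind of change is a 4.5-fold higher number from compound 1 to compound 3 (0.65 log units; beyond the scatter), a modest rise when the substituent on that saturated chain carbon was cut down; a 1.7-fold lower number from compound 2 to compound 3 (0.22 log units; within the scatter) lay within scatter. Going by the values given here, since compound 4 removes the remaining aromatic ring on that arm, a further modest rise in this assay is expected, though only one step supports it. Compound 4 is estimated at 6500 nM, range 2500 nM to 17000 nM, an expected step of a 1.5-fold higher number from compound 3 to compound 4 (0.19 log units; within the scatter).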

Compound 4, half-maximal effective concentration: 2900 nM
Estimate against measurement, compound 4: 2.2-fold (0.35 log units) above; the measured number falls inside the stated range.
By their numbers in this assay, from the lowest: compound 1; then compounds 4, 3 and 2 (each within the scatter of the next, the first and the last beyond it).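

Removing the ring from this arm, with isopropyl in place of benzyl on a saturated chain carbon bound to an aromatic carbon, gives no reading beyond the scatter in this assay (a 1.5-fold lower number from compound 3 to compound 4 (0.16 log units; within the scatter)). Compound 4 remains apart from both other arms, with a 3.1-fold higher number from compound 1 to compound 4 (0.49 log units; beyond the scatter) and a 2.4-fold lower number from compound 2 to compound 4 (0.39 log units; beyond the scatter), so among the saturated chain carbon arms shown, only 3,5-dimethylphenyl stands apart from benzyl and isopropyl. No measured evidence accounts for these steps. Open, on these data alone, is how an amine or a carboxylic acid on this arm would read in this assay.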